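This account rests on a few compounds, and the source may have more. Where it says the series, first, only, none or still open, it means among the compounds named here.

Compound 1 `Cc1ccc(C(=O)C2=C(O)C(=O)N(CC(C)O)C2c2ccc(C(C)C)cc2)cc1`: 101% in an assay on isolated protein for inhibition of annexin A2/S100-A10 (Homo sapiens), with a stated time of 5 min, tested at 50 uM; a lower number here means less inhibition, a higher number more inhibition at the concentration tested (going by the name of the read-out)
Compound 2 `Cc1ccc(C(=O)C2=C(O)C(=O)N(CC(C)O)C2c2cc(Cl)cc(Cl)c2)cc1`: 119% in this assay

Compound 1 stands lowest of the two numbers; its nearest neighbour, compound 2, shows a number 18 percentage points higher from compound 1 to compound 2 (beyond the scatter), a change made where a saturated ring carbon carries an aromatic ring. Compound 3 `CCOc1ccccc1C(=O)C1=C(O)C(=O)N(CC(C)O)C1c1ccc(C(C)C)cc1` differs from compound 1 elsewhere: 2-ethoxyphenyl in place of 4-methylphenyl on a carbonyl carbon. Within the data shown here, no measured step touches that carbonyl-attached ring, so the one step seen, from compound 1 to compound 2, does not bear directly on this change; it only shows that the number in this assay was higher for compound 2 than for compound 1 after a changed aromatic ring at that saturated ring carbon. With nothing closer to go by, the expectation for compound 3 is a step no larger than the usual scatter, a number 6 percentage points lower from compound 1 to compound 3 (within the scatter). Compound 3 is therefore estimated at 95%, with a range from 70% to 115%.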

Compound 3, a percentage reported as inhibition, at one concentration (the size of the read-out at that concentration, not a potency): 112%
The estimate for compound 3 lay 17 percentage points below the measured number, and the stated range covers the measured number.
By their numbers in this assay, from the lowest: compound 1; then compounds 3 and 2 (each within the scatter of the next).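

The ring on the carbonyl carbon turns out to be open to change in this assay: 2-ethoxyphenyl in place of 4-methylphenyl gives a number 11 percentage points higher from compound 1 to compound 3 (beyond the scatter), so this position, like the saturated ring carbon, can shift the number. The change did not lower the number, even though the entering group carries an oxygen counted as a hydrogen-bond acceptor, which the leaving group lacks. No measurement explains the rise, and this single step cannot separate the contribution of the oxygen from that of the rest of the ethoxy group.

The compounds shown leave open how a plain phenyl, a 2-methoxyphenyl or a ring bearing an amine would read at this carbonyl carbon. They also leave open whether 2-ethoxyphenyl and the 3,5-dichlorophenyl of compound 2 would add up in one molecule.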